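Fluorine on the phenyl ring: what to expect for compound 4

The source may hold more compounds than are shown below. What is called first, only, known or untested is meant among the compounds shown, and "the series" means these compounds.

Measured compounds:
compound 1 `O=C(C1COc2ccccc2O1)N1N=C(c2ccc(Br)cc2)CC1c1ccccc1` — 6150 nM
compound 2 `O=C(c1ccc2c(c1)OCCO2)N1N=C(c2ccc(Br)cc2)CC1c1ccccc1` — 1790 nM
compound 3 `O=C(c1ccc2c(c1)OCCO2)N1N=C(c2ccccc2)CC1c1ccccc1` — 1370 nM

These three compounds share a core and were tested in a functional assay on WM 266-4 cells (Homo sapiens) for inhibition, read by MTT assay, with a stated time of 24 h; on this read-out lower numbers stand for stronger inhibition of growth and higher numbers for weaker inhibition of growth. Compound 2 stands second highest of the three numbers: compound 3 sits nearest, and the step of a 1.3-fold lower number from compound 2 to compound 3 (0.12 log units; within the scatter) lies within the scatter, while compound 1 sits furthest, with a 3.4-fold lower number from compound 1 to compound 2 (0.54 log units; beyond the scatter) beyond the scatter.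

Compound 4 `O=C(c1ccc2c(c1)OCCO2)N1N=C(c2ccc(Br)cc2)CC1c1ccc(F)cc1` has not yet been measured. It differs from compound 2 in one place: fluoro in place of hydrogen on an aromatic carbon. The fluoro enters on an aromatic carbon of a six-membered aromatic ring of carbon only, para to a large group.

Neither measured step touches this ring. For the measured compounds named here, the only step that changes a group on an aromatic carbon, a 1.3-fold lower number from compound 2 to compound 3 (0.12 log units; within the scatter), stayed within the scatter, though it concerns the other aryl ring. Going by the values given here, no step bears directly on the change from compound 2 to compound 4, so no shift beyond the scatter is expected in this assay, and the expected step is a 1.1-fold lower number from compound 2 to compound 4 (0.02 log units; within the scatter).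

For compound 4 the estimated value is 1700 nM, with a range of 700 nM to 4500 nM.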

Compound 4, concentration for 50% growth inhibition: 3260 nM
Beside the measured number, compound 4's estimate is 1.9-fold (0.28 log units) below it; measured number inside the range.
By their numbers in this assay, from the lowest: compounds 3, 2, 4 and 1 (each within the scatter of the next, the first and the last beyond it).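

For the compounds shown here, on the phenyl ring that no earlier step touched, going from phenyl to 4-fluorophenyl gives a 1.8-fold higher number from compound 2 to compound 4 (0.26 log units; within the scatter) in this assay, so this single-atom change on this ring does not separate compound 4 from compound 2 beyond the usual variation between repeats. Together with a 1.3-fold lower number from compound 2 to compound 3 (0.12 log units; within the scatter) on the other aryl ring, that makes two single-atom changes on aromatic carbons within the scatter, while the one step beyond it remains a 3.4-fold lower number from compound 1 to compound 2 (0.54 log units; beyond the scatter), a change in how the carbonyl carbon joins the benzodioxin group. Nothing available here explains this result.

As far as these compounds go, whether a chloro, a methoxy or an amine in the same place would give a step beyond the scatter remains open. From the compounds shown here alone, it is also open whether fluoro on this ring would behave the same way in compound 3, which carries hydrogen in place of bromo.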